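The source may report more compounds than this note shows. Statements on the series, on what has been measured and on what is new or still open speak of the compounds shown alone.

Measured compounds in a functional assay for antagonist activity at C-X-C chemokine receptor type 3 (Homo sapiens); on this read-out lower numbers stand for stronger inhibition and higher numbers for weaker inhibition:
compound 1 `CNC(=O)c1cnc(N2CCN(C3CCN(Cc4ccc[nH]4)CC3)[C@@H](C)C2)c(Cl)c1` — 8060 nM
compound 2 `CNC(=O)c1cnc(N2CCN(C3CCN(Cc4ccccn4)CC3)[C@@H](C)C2)c(Cl)c1` — 7990 nM
compound 3 `CNC(=O)c1cnc(N2CCN(C3CCN(Cc4ccc(Cl)cc4F)CC3)[C@@H](C)C2)c(Cl)c1` — 18 nM

In this assay compound 1 gives 8060 nM and compound 2 gives 7990 nM; the step of a 1.0-fold lower number from compound 1 to compound 2 (0.00 log units; within the scatter) shows that pyridin-2-yl and 1H-pyrrol-2-yl on the benzylic-type carbon are interchangeable on this read-out. Compound 3 gives 18 nM and stands lowest of the three numbers; the steps of a 450-fold lower number from compound 1 to compound 3 (2.65 log units; beyond the scatter) and a 440-fold lower number from compound 2 to compound 3 (2.65 log units; beyond the scatter) place it far beyond the scatter from both, so compound 3 is the most potent of the measured set.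

Compound 4 `CNC(=O)c1cnc(N2CCN(C3CCN(Cc4ccc(Cl)cc4Cl)CC3)[C@@H](C)C2)c(Cl)c1` differs from compound 3 by chloro in place of fluoro on an aromatic carbon. For the measured compounds named here, no measured step bears directly on this exchange: the two large steps that lead into compound 3 each replace the whole heteroaryl ring with 4-chloro-2-fluorophenyl, and compound 4 keeps that carbocyclic ring with its chloro group in place, changing only the second halogen. The expectation therefore rests on the retained ring rather than on any recorded halogen swap. The step of a 1.1-fold higher number from compound 3 to compound 4 (0.05 log units; within the scatter) is expected to stay within the scatter, with no clear direction. For compound 4 the estimated value is 20 nM, with a range from 7 nM to 60 nM.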

Compound 4, half-maximal inhibitory concentration: 17 nM
Compound 4: middle estimate off by 1.2-fold (0.07 log units), on the high side; the range from low to high includes it.
By their numbers in this assay, from the lowest: compounds 4 and 3 (each within the scatter of the next); then compounds 2 and 1 (each within the scatter of the next).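

In this assay, for the compounds shown here, chloro in place of fluoro on an aromatic carbon of the six-membered aromatic ring of carbon only, ortho to a large group and meta to a chloro group, gives a 1.1-fold lower number from compound 3 to compound 4 (0.02 log units; within the scatter), the first reading of a change at this position, and the two halogens cannot be told apart on this read-out. The large gaps to the heteroaryl compounds persist with 2,4-dichlorophenyl, at a 470-fold lower number from compound 2 to compound 4 (2.67 log units; beyond the scatter) and a 470-fold lower number from compound 1 to compound 4 (2.68 log units; beyond the scatter), so among these compounds the low number does not depend on fluoro specifically. No supporting measurement bears on why the two halogens read alike.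

The compounds shown leave open what a methyl, a methoxy or a nitrile would do on this same aromatic carbon, and whether a plain hydrogen there would hold the number. Also open, from the compounds shown here alone, is how much of the gap to compound 1 and compound 2 belongs to the carbocyclic ring itself and how much to its halogens: compound 3 and compound 4 both carry the chloro group, and a plain benzyl would separate the two.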